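Moving the amino group on the aryl ring

A few compounds are considered here, and "the series" means these few. Any claim that something is new, unique, unknown or untested is made for them only; others in the source may bear on it.

Among the compounds with values here, compound 1 `COc1cc2c(cc1OC)C(c1ccc([N+](=O)[O-])cc1)=NNC(=O)C2` is the first member; in a functional assay on the whole organism with Mus musculus as the target (on this read-out lower numbers stand for an effect already at smaller amounts and higher numbers for an effect only at larger amounts of compound), compound 1 gives only a limit, > 120 umol/kg. Compound 2 `COc1cc2c(cc1OC)C(c1ccc(N)cc1)=NN=C(S)C2` gives 6.3 umol/kg in this assay. Among the values shown, compound 2 holds the only number; the remaining entry is a limit, and that limit is the limit of > 120 umol/kg in this assay, at which 1 of the 2 values shown sits, for compound 1. Compound 3 `COc1cc2c(cc1OC)C(c1cccc(N)c1)=NN=C(S)C2` differs from compound 2 by 3-aminophenyl in place of 4-aminophenyl on a carbon with a double bond to nitrogen. Within the data shown here, no measured step of this kind exists, so the step from compound 2 to compound 3 is estimated as small, a 1.6-fold higher number from compound 2 to compound 3 (0.20 log units; within the scatter), leaning toward a modest loss. Compound 3 is expected at 10 umol/kg, with a likely range from 4 umol/kg to 30 umol/kg.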

Compound 3, dose for half-maximal effect: 18.8 umol/kg
Compound 3: the middle estimate sits 1.9-fold (0.27 log units) below what was measured; measured number inside the range.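

The amino group's place on the aryl ring matters on the carbon with a double bond to nitrogen: in this assay, the swap gives a 3.0-fold higher number from compound 2 to compound 3 (0.47 log units; beyond the scatter) with the atom counts unchanged. Of this pair, 4-aminophenyl therefore carries the lower number, and the step lies beyond the usual scatter. Nothing shown accounts for the size of this step.

On these data alone, whether a dimethylamino or hydroxyl group in place of the amino group would keep the lower number stays open. Also open, as far as these compounds go, is how far this step carries over to other aryl substituents on the shared core.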